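A Second Chloro on the Fused Core of Compound 1

This account rests on a few compounds, and the source may have more. Where it says the series, first, only, none or still open, it means among the compounds named here.

Compound 1, `ClCc1ccc(Cn2cnc3c(Cl)ncnc32)cc1`, gives 660 nM in a functional assay on HCC 2998 cells (Homo sapiens) for cytotoxicity, read by sulforhodamine B assay, with a stated time of 48 h; on this read-out lower numbers stand for stronger inhibition of growth and higher numbers for weaker inhibition of growth.
Compound 2, `ClCc1cccc(Cn2cnc3ncnc(Cl)c32)c1`, gives 1690 nM in this assay.
Compound 3, `ClCc1ccccc1Cn1cnc2ncnc(Cl)c21`, gives 2230 nM in this assay.

Of the three measured compounds, compound 1 shows the lowest number in this assay, and so the strongest inhibition of growth. Its nearest neighbour is compound 2, whose number is higher by a margin that lies beyond the usual scatter; compound 3 stands furthest away, again beyond the scatter. For the measured compounds named here, the three compounds differ from one another in the position of the chloromethyl substituent on the benzyl ring, but no pair of them differs in only one place, so no single step among them has been isolated.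

The next compound, compound 4, `ClCc1ccc(Cn2cnc3c(Cl)nc(Cl)nc32)cc1`, keeps everything in compound 1 and adds one atom: chloro in place of hydrogen on an aromatic carbon. Going by the values given here, no measured pair shows what such an added chloro does in this assay, so there is no precedent to lean on. Since compound 1 gives 660 nM and the change is a single small substituent, compound 4 is expected to stay close to that number, with either direction possible. Compound 4 is estimated at 550 nM, between 150 nM and 2000 nM. The expected step of a 1.2-fold lower number from compound 1 to compound 4 (0.08 log units; within the scatter) is therefore small, likely within the scatter.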

Compound 4, concentration for 50% growth inhibition: 10200 nM
Beside the measured number, compound 4's estimate is 19-fold (1.27 log units) below it; the measured number lies above the stated range.
By their numbers in this assay, from the lowest: compound 1; then compounds 2 and 3 (each within the scatter of the next); then compound 4.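

In this assay, chloro in place of hydrogen on an aromatic carbon, between two ring nitrogen atoms, gives a 15-fold higher number from compound 1 to compound 4 (1.19 log units; beyond the scatter), a large step towards weaker inhibition of growth. This shows that the position is not indifferent to substitution: in this one comparison, a single added chlorine atom, with no ring, hydrogen-bond donor, hydrogen-bond acceptor or net charge, is enough to change the read-out well beyond the scatter, something compounds 1, 2 and 3, which all carry hydrogen on this carbon, could not reveal. Nothing measured here bears on why the number rises so far.

The compounds shown leave open whether the loss is particular to chloro or would also follow from another group on this carbon, such as an amine, a methoxy group or a longer chain such as propyl. They also leave open whether the same change would carry a comparable penalty on compound 2 or compound 3, or in any cell line other than the one used here.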